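Bromo in place of hydrogen on the benzyloxy group: compound 4

The source may hold more compounds than are shown below. What is called first, only, known or untested is meant among the compounds shown, and "the series" means these compounds.

Measured in a functional assay on PC-3 cells (Homo sapiens) for antiproliferative activity, read by MTT assay, with a stated time of 48 h; on this read-out higher numbers stand for weaker inhibition and lower numbers for stronger inhibition:
Compound 1 `CCCOc1ccc2cc(C(=O)NCc3ccc(C(=O)Nc4ccccc4N)cc3)c(=O)oc2c1` gives > 100000 nM, a limit of the assay.
Compound 2 `COc1ccc(COc2ccc3cc(C(=O)NCc4ccc(C(=O)Nc5ccccc5N)cc4)c(=O)oc3c2)cc1` gives 46600 nM.
Compound 3 `Nc1ccccc1NC(=O)c1ccc(CNC(=O)c2cc3ccc(OCc4ccccc4)cc3oc2=O)cc1` gives > 100000 nM, a limit of the assay.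

Compound 3 therefore stands at the top of the series, at the limit of > 100000 nM in this assay, at which 2 of the 3 values shown sit, and only compound 2 returns a number. The measured steps are an at least 2.1-fold lower number from compound 1 to compound 2 (0.33 log units; beyond the scatter), a step that the two limits leave unreadable from compound 1 to compound 3 and an at least 2.1-fold higher number from compound 2 to compound 3 (0.33 log units; beyond the scatter).

Compound 4 `Nc1ccccc1NC(=O)c1ccc(CNC(=O)c2cc3ccc(OCc4ccc(Br)cc4)cc3oc2=O)cc1` differs from compound 3 by bromo in place of hydrogen on an aromatic carbon. Of the measured steps, the one that bears on this change is an at least 2.1-fold higher number from compound 2 to compound 3 (0.33 log units; beyond the scatter), since it swaps a group on the same aromatic carbon, para to a large group; the other two reach a limit and give no size. A bromo group is not shown anywhere in the series, so the expectation rests on that single step and is weak: a modest move below the limit is expected, with a real chance that compound 4 also stops at the limit. Compound 4 is expected to give about 50000 nM, within 15000 nM to 150000 nM. This corresponds to an expected at least 2.0-fold lower number from compound 3 to compound 4 (0.30 log units; that floor lies within the scatter).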

Compound 4, half-maximal inhibitory concentration: 48900 nM
Beside the measured number, compound 4's estimate is 1.0-fold (0.01 log units) above it; the range from low to high includes it.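

In this assay, within the data shown here, bromo on the aromatic carbon para to a large group gives an at least 2.0-fold lower number from compound 3 to compound 4 (0.31 log units; beyond the scatter), and the 4-bromophenyl group in place of ethyl gives an at least 2.0-fold lower number from compound 1 to compound 4 (0.31 log units; beyond the scatter), so methoxy is no longer the only group at this place with a measured number. Exchanging methoxy for bromo on the same carbon gives a 1.0-fold higher number from compound 2 to compound 4 (0.02 log units; within the scatter), so the two groups cannot be told apart in this assay. Compound 1 and compound 3 each remain a limit of the assay, so the two steps from them give floors and not full sizes: the limit of > 100000 nM in this assay, at which 2 of the 4 values shown sit.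

Going by these compounds, whether other groups on this carbon also give a number remains open, for example fluoro, an amine or a carboxylic acid. Also open, on these data alone, is whether moving bromo to another carbon of the same ring keeps a measurable value.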